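Thiophene regioisomers on an azetidinone core against breast cancer cells

This account rests on a few compounds, and the source may have more. Where it says the series, first, only, none or still open, it means among the compounds named here.

Three compounds in this set were tested in a functional assay on MCF7 cells (Homo sapiens) for antiproliferative activity, read by MTT assay; a higher number here means a weaker inhibitor, a lower number a stronger inhibitor. Compound 3 `COc1ccc([C@@H]2[C@@H](c3cccs3)C(=O)N2c2cc(OC)c(OC)c(OC)c2)cc1O` gives 7 nM. Compound 1 `COc1ccc([C@@H]2[C@@H](c3ccsc3)C(=O)N2c2cc(OC)c(OC)c(OC)c2)cc1O` gives 10 nM, and the change between them is thiophen-3-yl in place of thiophen-2-yl on a saturated ring carbon, which made a step of a 1.4-fold higher number from compound 3 to compound 1 (0.15 log units; within the scatter). Compound 2 `COc1ccc([C@@H]2C(c3cccs3)C(=O)N2c2cc(OC)c(OC)c(OC)c2)cc1` gives 64 nM in this assay, the highest of the three numbers; the difference between the core of compound 2 and the core of compound 3 is not broken down here. Compound 4 `COc1ccc([C@@H]2C(c3ccsc3)C(=O)N2c2cc(OC)c(OC)c(OC)c2)cc1` has not yet been measured. It differs from compound 2 by thiophen-3-yl in place of thiophen-2-yl on a saturated ring carbon. This is the same kind of change as that from compound 3 to compound 1, not the same one: there the saturated ring carbon sits next to the ring atom that bears a 3-hydroxy-4-methoxyphenyl group, here next to the ring atom that bears a 4-methoxyphenyl group. Because the earlier step was a 1.4-fold higher number from compound 3 to compound 1 (0.15 log units; within the scatter), the expected step from compound 2 to compound 4 in this assay is a 1.3-fold higher number from compound 2 to compound 4 (0.10 log units; within the scatter). Compound 4 is therefore estimated at 80 nM, with a range expected from 35 nM to 180 nM.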

Compound 4, half-maximal inhibitory concentration: 60 nM
Compound 4: middle estimate off by 1.3-fold (0.12 log units), on the high side; the range from low to high includes it.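

In this assay, thiophen-3-yl in place of thiophen-2-yl on a saturated ring carbon gave a 1.1-fold lower number from compound 2 to compound 4 (0.03 log units; within the scatter), and the earlier step with this change also lay within the scatter. The change thus carried from one core to the other without a difference that these data can separate: the same change on two cores in this assay, a 1.4-fold higher number (0.15 log units; within the scatter) from compound 3 to compound 1 and a 1.1-fold lower number (0.03 log units; within the scatter) from compound 2 to compound 4, 1.5-fold (0.18 log units) apart, within the scatter of two such steps. Within the data shown here, this rests on only two pairs, so it shows that the two thiophene attachments are interchangeable within the scatter on these two cores, but it does not show that the same would hold on any other core.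

The compounds shown carry only thiophen-2-yl and thiophen-3-yl at this place, so it remains open how a furan-2-yl, a pyridin-3-yl or a plain phenyl group would read there. From the compounds shown here alone, it also remains open whether the change would carry to a core with an amine in place of the hydroxy group of compound 1.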